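The compounds below may be only part of what the source reports. "The series", "measured", "known", "first", "only" and "open" are said of these compounds alone.

Compound 1 `CCOC(=O)C1(C(=O)Nc2ccc(F)cc2)CC1c1cc(OC)c(OC)c(OC)c1`: 79100 nM; 36100 nM (2 entries)
Compound 2 `COc1cc([C@H]2C[C@@]2(CO)C(=O)Nc2ccccc2)cc(OC)c1OC`: > 100000 nM

Both compounds were tested in a functional assay on QGY cells (Homo sapiens) for cytotoxicity, read by MTT assay, with a stated time of 48 h; on this read-out higher numbers stand for weaker inhibition and lower numbers for stronger inhibition. Compound 1 gives 79100 nM; 36100 nM (2 entries) in this assay, as the several entries of compound 1 in this assay, 79100 nM; 36100 nM (2 entries) shows. For compound 2 the result is only a limit, > 100000 nM, with a further entry that carries no single number. the limit of > 100000 nM in this assay, at which 1 of the 2 values shown sits, places compound 2 at the edge of what this assay reports, so among the two compounds shown it stands without a value of its own rather than with a weak one. The change from compound 2 to compound 3 `COc1cc([C@H]2C[C@@]2(CO)C(=O)NCc2ccc(C)cc2)cc(OC)c1OC` is 4-methylbenzyl in place of phenyl on an amide-type nitrogen. Going by the values given here, no measured pair of compounds shares this change, so the numbers give no step to lean on. Because the limit of > 100000 nM in this assay, at which 1 of the 2 values shown sits, leaves compound 2 without a number, the expected change in this assay, an at least 1.1-fold lower number from compound 2 to compound 3 (0.04 log units; that floor lies within the scatter), is taken as none beyond the scatter, in either direction. Compound 3 is therefore expected to give about 90000 nM, within a range from 30000 nM to 250000 nM, and with a fair chance that this assay again reports only a limit.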

Compound 3, half-maximal inhibitory concentration: > 100000 nM
Compound 3: no number, only a limit; the forecaster's own chance of this, stated with the estimate: 50%; middle value at least 1.1-fold (0.04 log units) away from the limit.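

In this assay compound 3 gives > 100000 nM, which is a limit and not a number. Going by these compounds alone, compound 2 also stands only at a limit, so no step from compound 2 to compound 3 can be read. The compounds shown leave open whether 4-methylbenzyl in place of phenyl on the amide-type nitrogen changes the read-out at all.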